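A few compounds are considered here, and "the series" means these few. Any claim that something is new, unique, unknown or untested is made for them only; others in the source may bear on it.

Within the data shown here, compound 3 `CCCN1CCC(c2noc(COc3ccc(CCC(=O)NO)cc3)n2)CC1` gives 13% in an assay on isolated protein for inhibition of protein deacetylase HDAC6 (Homo sapiens), read by fluorescence, with a stated time of 1 h, tested at 100 nM (on this read-out lower numbers stand for less inhibition and higher numbers for more inhibition at the one concentration tested (going by the name of the read-out)), the lowest of the three numbers measured so far. Compound 1 `CCCN1CCC(c2noc(COc3ccc(/C=C/C(=O)NO)cc3)n2)CC1` gives 69% and compound 2 `C=CCN1CCC(c2noc(COc3ccc(/C=C/C(=O)NO)cc3)n2)CC1` gives 66% in this assay. Compound 4 `C=CCN1CCC(c2noc(COc3ccc(CCC(=O)NO)cc3)n2)CC1` differs from compound 3 by vinyl in place of ethyl on a saturated chain carbon bound to an amine nitrogen in a ring. The same change has been made once before: a number 3 percentage points lower from compound 1 to compound 2 (within the scatter). The other change seen, 2-(hydroxycarbamoyl)ethyl in place of 2-(hydroxycarbamoyl)ethenyl on an aromatic carbon, gave a number 56 percentage points lower from compound 1 to compound 3 (beyond the scatter), and compound 4 keeps that group from compound 3. The step from compound 3 to compound 4 is therefore expected to be small, a number 1 percentage points lower from compound 3 to compound 4 (within the scatter), with no direction beyond the scatter. Compound 4 is estimated at 12%, in the range 0% to 28%.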

Compound 4, a percentage reported as inhibition, at one concentration (the size of the read-out at that concentration, not a potency): 15%
Beside the measured number, compound 4's estimate is 3 percentage points below it, and the stated range covers the measured number.
By their numbers in this assay, from the lowest: compounds 3 and 4 (each within the scatter of the next); then compounds 2 and 1 (each within the scatter of the next).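

Vinyl in place of ethyl on a saturated chain carbon bound to an amine nitrogen in a ring now also leaves the saturated series unmoved, a number 2 percentage points higher from compound 3 to compound 4 (within the scatter), so in this assay this change shifts the number on neither core: the same change on two cores in this assay, a number 3 percentage points lower (within the scatter) from compound 1 to compound 2 and a number 2 percentage points higher (within the scatter) from compound 3 to compound 4, 5 percentage points apart, within the scatter of two such steps. The drop with 2-(hydroxycarbamoyl)ethyl in place of 2-(hydroxycarbamoyl)ethenyl also returns with allyl in place of propyl, a number 51 percentage points lower from compound 2 to compound 4 (beyond the scatter): the same change on two cores in this assay, a number 56 percentage points lower (beyond the scatter) from compound 1 to compound 3 and a number 51 percentage points lower (beyond the scatter) from compound 2 to compound 4, 5 percentage points apart, within the scatter of two such steps. Going by these compounds, only propyl and allyl appear on that amine nitrogen, so whether a benzyl group or a longer chain ending in a carboxylic acid would also leave the number unmoved stays open.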